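Sulfonyl substituent change in the aryl vinyl sulfone series

This account rests on a few compounds, and the source may have more. Where it says the series, first, only, none or still open, it means among the compounds named here.

Within the data shown here, compound 3 `COc1ccccc1/C=C(\C(=O)c1ccc(Cl)cc1)S(=O)(=O)c1ccc(C)cc1` holds the lowest number of the three measured members in a functional assay on DU-145 cells (Homo sapiens) for inhibition, read by trypan blue exclusion, with a stated time of 96 h; a higher number here means a weaker inhibitor of growth, a lower number a stronger inhibitor of growth: compound 3 gives 1000 nM. Its nearest neighbour is compound 2 `Cc1ccc(S(=O)(=O)/C(=C/c2ccccc2F)C(=O)c2ccc(Cl)cc2)cc1`, which in this assay gives 2500 nM; the step of a 2.5-fold lower number from compound 2 to compound 3 (0.40 log units; beyond the scatter) is modest but beyond the scatter. Compound 1 `Cc1ccc(S(=O)(=O)/C(=C/c2ccc(C)s2)C(=O)c2ccc(Cl)cc2)cc1`, which in this assay gives 50000 nM, stands furthest away: a 50-fold lower number from compound 1 to compound 3 (1.70 log units; beyond the scatter) and a 20-fold lower number from compound 1 to compound 2 (1.30 log units; beyond the scatter) are both large. All three measured steps alter the group on the double-bonded chain carbon bound to a double-bonded chain carbon, or a substituent on that aromatic ring; the sulfonyl side of the shared core stays the same throughout.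

Compound 4 `COc1ccccc1/C=C(\C(=O)c1ccc(Cl)cc1)S(=O)(=O)Cc1ccc(Cl)cc1` differs from compound 3 at that untouched position: 4-chlorobenzyl in place of 4-methylphenyl on a sulfonyl sulfur. Among the measured compounds shown here, no measured step bears on this change, so the expectation can rest only on the shared core and the measured value of compound 3. For the measured compounds named here, the data give no precedent for altering the group on the sulfonyl sulfur, so no shift beyond the scatter is expected, with a wide range to reflect that uncertainty. Compound 4 is estimated at 1000 nM (range 300 nM to 4000 nM), and the step of no change at the digits printed from compound 3 to compound 4 (within the scatter) is accordingly expected to lie within the scatter.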

Compound 4, concentration for 50% growth inhibition: 25000 nM
For compound 4 the middle estimate is 25-fold (1.40 log units) below the measured one; measured number above the stated range.
By their numbers in this assay, from the lowest: compound 3; then compound 2; then compounds 4 and 1 (each within the scatter of the next).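

The sulfonyl sulfur is not a silent position in this assay: with the rest of the shared core held constant, 4-chlorobenzyl in place of 4-methylphenyl brings a 25-fold higher number from compound 3 to compound 4 (1.40 log units; beyond the scatter) as a large step. Among these compounds, the earlier steps showed only that the number moves with the group on the double-bonded chain carbon, or with a substituent on that aromatic ring, whereas this one shows that the sulfonyl side also moves it, and towards a weaker inhibitor of growth. Nothing shown here accounts for the size of this step.

The change swaps a ring bound directly to the sulfonyl sulfur for a benzyl group and a methyl substituent for a chlorine, so the compounds shown leave open which of the two goes with the higher number; a 4-chlorophenyl or a 4-methylbenzyl group on the sulfonyl sulfur would separate them. Also open, from the compounds shown here alone, is whether the same change would give a step of similar size in the 2-fluorophenyl member, compound 2, and how a small group such as methyl on the sulfonyl sulfur would compare.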